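Triazolylmethyl substituents on the indole nitrogen of the parent core

A few compounds are considered here, and "the series" means these few. Any claim that something is new, unique, unknown or untested is made for them only; others in the source may bear on it.

The parent of the series is compound 1 `O=C1c2c[n+]([O-])c3ccccc3c2C(=O)c2[nH]c3ccccc3c21`. For the measured compounds named here, in a functional assay on A549 cells (Homo sapiens) for cytotoxicity, read by MTT assay, with a stated time of 72 h (on this read-out higher numbers stand for weaker inhibition and lower numbers for stronger inhibition), compound 1 gives 320 nM, the lowest of the three numbers so far. Compound 2 `O=C1c2c[n+]([O-])c3ccccc3c2C(=O)c2c1c1ccccc1n2Cc1cn([C@H]2O[C@H](CO)[C@@H](O)[C@H]2O)nn1` carries a triazolylmethyl group bearing the 3,4-dihydroxy-5-(hydroxymethyl)oxolan-2-yl; in this assay compound 2 gives 2680 nM, well above compound 1. Compound 3 `CC1(C)OC[C@H](Cn2cc(Cn3c4c(c5ccccc53)C(=O)c3c[n+]([O-])c5ccccc5c3C4=O)nn2)O1` carries the same triazolylmethyl group with the (2,2-dimethyl-1,3-dioxolan-4-yl)methyl instead; in this assay compound 3 gives 340 nM, within the scatter of compound 1. Going by the values given here, the one single-point step measured so far is a 7.9-fold lower number from compound 2 to compound 3 (0.90 log units; beyond the scatter).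

Compound 4 `O=C1c2c[n+]([O-])c3ccccc3c2C(=O)c2c1c1ccccc1n2Cc1cn(C[C@H](O)CO)nn1` is the next member. It differs from compound 1 by (1-(2,3-dihydroxypropyl)-1H-1,2,3-triazol-4-yl)methyl in place of hydrogen on an aromatic nitrogen. Among the compounds with values here, no measured step covers exactly this change. The bearing data are the pair of compound 1 and compound 3, which show that the triazolylmethyl group itself can sit on this nitrogen without moving the number beyond the scatter, and the step from compound 2 to compound 3, which shows that the substituent on the triazole matters. Compound 4 carries the 2,3-dihydroxypropyl, which is smaller than the group of compound 2 but shares its hydroxyls, so the expected result for compound 4 is a step of a 2.3-fold higher number from compound 1 to compound 4 (0.37 log units; beyond the scatter), a modest rise in the number. Compound 4 is estimated at 750 nM, in the range 250 nM to 2200 nM.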

Compound 4, half-maximal inhibitory concentration: 1030 nM
Estimate against measurement, compound 4: 1.4-fold (0.14 log units) below; the range from low to high includes it.
By their numbers in this assay, from the lowest: compounds 1 and 3 (each within the scatter of the next); then compound 4; then compound 2.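

With this assay as the read-out, the substituent on the triazole now gives a graded series rather than a two-point contrast: the 1,2-dihydroxyethyl in place of the 2,2-dimethyl-1,3-dioxolan-4-yl gives a 3.0-fold higher number from compound 3 to compound 4 (0.48 log units; beyond the scatter) and so loses part of what compound 3 retains, while the 2,3-dihydroxypropyl in place of the 3,4-dihydroxy-5-(hydroxymethyl)oxolan-2-yl gives a 2.6-fold lower number from compound 2 to compound 4 (0.42 log units; beyond the scatter) and so recovers part of what compound 2 loses. Substitution on the aromatic nitrogen of the parent is therefore not neutral for every triazolylmethyl group, since a 3.2-fold higher number from compound 1 to compound 4 (0.51 log units; beyond the scatter) is beyond the scatter, whereas compound 3 stays within the scatter of compound 1. Among the three substituted compounds, the two carrying free hydroxyls, compound 2 and compound 4, have the higher numbers, but no measured evidence accounts for this ordering.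

The compounds shown leave open how an amine, a carboxylic acid or a longer unbranched alkyl chain on the triazole would read compared with the diol and the dioxolane. They also leave open whether a plain methyl on the aromatic nitrogen, without the triazole, would stay with compound 1.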